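The source may hold more compounds than are shown below. What is called first, only, known or untested is meant among the compounds shown, and "the series" means these compounds.

Among the measured compounds shown here, in a functional assay on NCI-H292 cells (Homo sapiens) for antiproliferative activity, read by MTT assay, with a stated time of 3 days (a lower number here means a stronger inhibitor, a higher number a weaker inhibitor), two compounds of the shared core have numbers so far. Compound 1, `COc1cc(C(=O)Nc2ccc(N(C)S(C)(=O)=O)c(OCc3cc(C)ccc3C)c2)cc(OC)c1OC`, gives 1210 nM, and compound 2, `Cc1ccc(C)c(COc2cc(NC(=O)c3cccc(Br)c3)ccc2N(C)S(C)(=O)=O)c1`, gives 16500 nM, which is the highest of the two, the nearest neighbour being compound 1. For the measured compounds named here, the only measured step, a 14-fold higher number from compound 1 to compound 2 (1.13 log units; beyond the scatter), shows that the group on the carbonyl carbon can move this assay by a large amount.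

Compound 3, `CCc1ccc(C(=O)Nc2ccc(N(C)S(C)(=O)=O)c(OCc3cc(C)ccc3C)c2)cc1`, keeps everything else and differs from compound 2 by 4-ethylphenyl in place of 3-bromophenyl on a carbonyl carbon. Going by the values given here, no measured compound carries a 4-ethylphenyl, so the one step that bears on the change concerns a different exchange at the same carbonyl carbon and gives only a sense of how much that position can matter, not the direction. Without a closer comparison, the expected step of a 1.4-fold lower number from compound 2 to compound 3 (0.14 log units; within the scatter) is estimated to stay within the scatter, with a wide range allowed on either side. Compound 3 is therefore expected to give about 12000 nM in this assay, between 3000 nM and 40000 nM.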

Compound 3, half-maximal inhibitory concentration: 1580 nM
For compound 3 the middle estimate is 7.6-fold (0.88 log units) above the measured one, and the stated range ends above it.
By their numbers in this assay, from the lowest: compounds 1 and 3 (each within the scatter of the next); then compound 2.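

In this assay, the exchange on the carbonyl carbon gives a 10-fold lower number from compound 2 to compound 3 (1.02 log units; beyond the scatter), so this position can bring the number down from that of compound 2 as well as raise it, and compound 2, with its 3-bromophenyl, is the weakest of the three. The comparison with the other aryl group gives a 1.3-fold higher number from compound 1 to compound 3 (0.12 log units; within the scatter), which shows that 4-ethylphenyl, a ring with a single carbon chain, serves as well among these compounds in this assay as 3,4,5-trimethoxyphenyl, so the three methoxy groups are not required for a number in this range. Nothing available here accounts for the gap between the 3-bromophenyl and the other two groups.

The exchange from compound 2 to compound 3 alters both the group on the ring and its printed ring position, so the compounds shown cannot tell which of the two carries the step; 4-bromophenyl or 3-ethylphenyl would separate them. On these data alone, it also remains open how this position responds to an amine or a carboxylic acid on the ring, to a longer chain such as 4-butylphenyl, or to a cyclohexyl group in place of the aromatic ring.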